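The source may report more compounds than this note shows. Statements on the series, on what has been measured and on what is new or still open speak of the compounds shown alone.

Compound 1 `CCO/C(O)=C1\C(C)=NC(C)=C(C(=O)OCCCN2C(=O)c3ccccc3S2(=O)=O)C1c1cccc(Cl)c1Cl` is measured in a functional assay (aorta) with Oryctolagus cuniculus as the target (on this read-out lower numbers stand for stronger inhibition and higher numbers for weaker inhibition), where compound 1 gives 1.8 nM. Within the data shown here, the only comparison at hand is compound 2 `CC1=NC(C)=C(C(=O)OCCCN2C(=O)c3ccccc3S2(=O)=O)C(c2cccc(Cl)c2Cl)/C1=C(\O)OC(C)(C)C`, which in this assay gives 3.1 nM; the step of a 1.7-fold higher number from compound 1 to compound 2 (0.24 log units; within the scatter) concerns a tert-butyl in place of ethyl on an oxygen on an unsaturated carbon and leaves the two compounds level within the scatter. Among the measured compounds shown here, compound 3 `CCO/C(O)=C1\C(C)=NC(C)=C(C(=O)OCCCN2C(=O)c3ccccc3S2(=O)=O)C1c1ccccc1Cl` carries a different change, (hydrogen in place of chloro on an aromatic carbon), on the aromatic ring, and no measured step touches that ring. For this assay a modest weakening is therefore expected for compound 3, estimated at 5 nM with a range from 1.5 nM to 20 nM, a step of a 2.8-fold higher number from compound 1 to compound 3 (0.44 log units; beyond the scatter) for which nothing already in hand gives a precedent.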

Compound 3, half-maximal inhibitory concentration: 3.9 nM
For compound 3 the middle estimate is 1.3-fold (0.11 log units) above the measured one; low and high end bracket the measured number.
By their numbers in this assay, from the lowest: compounds 1, 2 and 3 (each within the scatter of the next, the first and the last beyond it).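

In this assay the change from 2,3-dichlorophenyl to 2-chlorophenyl gives a 2.2-fold higher number from compound 1 to compound 3 (0.34 log units; beyond the scatter) and is a modest step, the first measured on the aromatic ring rather than on the oxygen substituent. The chloro group at this position therefore has a measurable but limited effect on the number. No supporting measurement accounts for this step. From the compounds shown here alone, what remains open is whether the remaining chloro group matters as much, and how a methoxy or nitro group would compare with chloro at this position.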